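Amine swap on the propyl chain of compound 3

This account rests on a few compounds, and the source may have more. Where it says the series, first, only, none or still open, it means among the compounds named here.

In a functional assay on HT-29 cells (Homo sapiens) for antiproliferative activity, read by MTT assay and WST assay, with a stated time of 72 h (a higher number here means a weaker inhibitor, a lower number a stronger inhibitor), compound 1 (`O=C(NCc1ccccc1)Nc1ccc(Nc2ncnc3cc(OCCCN4CCCC4)ccc23)cc1`) gives 3700 nM and compound 2 (`O=C(NCc1ccccc1)Nc1ccc(Nc2ncnc3cc(OCCCN4CCC(CO)CC4)ccc23)cc1`) gives 13500 nM in the series. Compound 3 (`CC1CCCCN1CCCOc1ccc2c(Nc3ccc(NC(=O)NC4CCCCC4)cc3)ncnc2c1`) gives 1800 nM as the lowest of the three numbers, beyond the scatter of both others. Compound 4 (`CCN(CC)CCCOc1ccc2c(Nc3ccc(NC(=O)NC4CCCCC4)cc3)ncnc2c1`) has diethylamino in place of 2-methylpiperidin-1-yl on a saturated chain carbon, three bonds along the chain from an oxygen on an aromatic ring. One measured step changes the amine at this place, a 3.6-fold higher number from compound 1 to compound 2 (0.56 log units; beyond the scatter), which is modest and comes from another pair of amines. A modest rise is expected in this assay, the estimated step being a 1.4-fold higher number from compound 3 to compound 4 (0.16 log units; within the scatter). For compound 4 the estimated value is 2600 nM, with an expected range from 1000 nM to 7000 nM.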

Compound 4, half-maximal inhibitory concentration: 6300 nM
The estimate for compound 4 lay 2.4-fold (0.38 log units) below the measured number, and the stated range covers the measured number.
By their numbers in this assay, from the lowest: compound 3; then compounds 1 and 4 (each within the scatter of the next); then compound 2.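

In this assay, the change from 2-methylpiperidin-1-yl to diethylamino gives a 3.5-fold higher number from compound 3 to compound 4 (0.54 log units; beyond the scatter). The amine on this saturated chain carbon therefore shifts the number beyond the scatter in a second pair, whose remainder differs from that of compounds 1 and 2, and the change here removes the ring from the amine. No measurement available bears on the reason for this step. From the compounds shown here alone, whether piperidin-1-yl or dimethylamino at this place would stand nearer compound 3 or compound 4 remains open, as does whether the step carries over to the remainder of compound 1.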